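The compounds below may be only part of what the source reports. "The series", "measured", "known", "first", "only" and "open" are said of these compounds alone.

- Compound 1 `C=C/C=C\[C@H](C)[C@H](OC(N)=O)[C@@H](C)[C@H](O)[C@@H](C)C/C(C)=C\[C@H](C)[C@@H](O)[C@@H](C)/C=C\CCc1cccc(F)c1`: 400 nM
- Compound 2 `C=C/C=C\[C@H](C)[C@H](OC(N)=O)[C@@H](C)[C@H](O)[C@@H](C)C/C(C)=C\[C@H](C)[C@@H](O)[C@@H](C)/C=C\CCc1ccccc1`: 350 nM

Going by the values given here, in a functional assay on SK-OV-3 cells (Homo sapiens) for cytotoxicity (on this read-out lower numbers stand for stronger inhibition and higher numbers for weaker inhibition), compound 1, the only other compound measured, stands level with compound 2 at 350 nM. Compound 3 `C=C/C=C\[C@H](C)[C@H](OC(N)=O)[C@@H](C)[C@H](O)[C@@H](C)C/C(C)=C\[C@H](C)[C@@H](O)[C@@H](C)/C=C\CCc1cccc(O)c1` differs from compound 2 by hydroxy in place of hydrogen on an aromatic carbon, meta to a large group. Among the compounds with values here, one measured step bears on this, the exchange of fluoro for hydrogen on an aromatic carbon, a 1.1-fold lower number from compound 1 to compound 2 (0.06 log units; within the scatter). Within the data shown here, no measured compound carries hydroxy, so this is weak guidance, and no step beyond the scatter is expected in this assay. The expected step is a 1.1-fold higher number from compound 2 to compound 3 (0.06 log units; within the scatter). Compound 3 is estimated at 400 nM, with an expected range of 130 nM to 1200 nM.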

Compound 3, half-maximal inhibitory concentration: 40 nM
Beside the measured number, compound 3's estimate is 10-fold (1.00 log units) above it, and the stated range ends above it.
By their numbers in this assay, from the lowest: compound 3; then compounds 2 and 1 (each within the scatter of the next).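

In this assay this aromatic carbon proved sensitive to its substituent: hydroxy in place of hydrogen gives an 8.8-fold lower number from compound 2 to compound 3 (0.94 log units; beyond the scatter) and hydroxy in place of fluoro gives a 10-fold lower number from compound 1 to compound 3 (1.00 log units; beyond the scatter), whereas fluoro and hydrogen stayed within the scatter of each other. Of the three groups at this place, only hydroxy stands apart. The data shown offer no explanation for this. As far as these compounds go, whether an amine, a methoxy group or a carboxylic acid at this place would match hydroxy remains open, as does the effect of hydroxy on another carbon of the ring.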